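This account rests on a few compounds, and the source may have more. Where it says the series, first, only, none or still open, it means among the compounds named here.

Working notes on the series. Compound 1 `ClCc1ccccc1Cn1cnc2c(Cl)ncnc21`, compound 2 `ClCc1cccc(Cn2cnc3ncnc(Cl)c32)c1` and compound 3 `ClCc1cccc(Cn2cnc3c(Cl)ncnc32)c1` share one core and differ in where the chloromethyl-bearing benzyl arm is attached and how the core is oriented. In a functional assay on MDA-MB-435 cells (Homo sapiens) for cytotoxicity, read by sulforhodamine B assay, with a stated time of 48 h (on this read-out lower numbers stand for stronger inhibition of growth and higher numbers for weaker inhibition of growth), compound 1 gives 3020 nM, compound 2 gives 3460 nM and compound 3 gives 1690 nM. Compound 3 has the lowest of the three numbers; its gap to compound 1 lies within the scatter, its gap to compound 2 just beyond it, so no ranking of compound 3 against compound 1 is claimed.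

Compound 4 `ClCc1cccc(Cn2cnc3c(Cl)nc(Cl)nc32)c1` differs from compound 3 by chloro in place of hydrogen on an aromatic carbon. For the measured compounds named here, no measured pair shows this change, so its size is unknown; a step no larger than the scatter is expected, leaning toward a lower number. The expected step of a 1.4-fold lower number from compound 3 to compound 4 (0.15 log units; within the scatter) is modest. Compound 4 is estimated at 1200 nM in this assay, with a range from 400 nM to 3500 nM.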

Compound 4, concentration for 50% growth inhibition: 1690 nM
The estimate for compound 4 lay 1.4-fold (0.15 log units) below the measured number; the range from low to high includes it.
By their numbers in this assay, from the lowest: compounds 3, 4, 1 and 2 (each within the scatter of the next, the first and the last beyond it).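

In this assay, chloro in place of hydrogen on the aromatic carbon between two ring nitrogen atoms gives no change at the digits printed from compound 3 to compound 4 (within the scatter). For the compounds shown here, this is the first reading at this position, and it shows that the added chloro leaves growth inhibition unmoved, with one pair as the only support. No data at hand bear on why the number stays flat. Still open, from the compounds shown here alone, is whether an amine or a methoxy group on this same carbon would shift the number, and whether chloro behaves alike with the chloromethyl-bearing benzyl arm attached as in compound 1.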